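Phenyl for Methyl on a Shared Kinase Core

The compounds below may be only part of what the source reports. "The series", "measured", "known", "first", "only" and "open" are said of these compounds alone.

Compound 1: `Cc1cc2c(c(N)nn2C)c(N2CCCCC2)n1` with 6%
Compound 2: `COCCNc1nc(C)cc2c1c(N)nn2C` with 6%

Compound 2 stands level with compound 1 in an assay on isolated protein for inhibition of RAC-alpha serine/threonine-protein kinase (Homo sapiens), read by mobility shift assay, tested at 30 uM; a higher number here means more inhibition at the concentration tested (going by the name of the read-out), a lower number less inhibition. Among the measured compounds shown here, the only measured step, no change at the digits printed from compound 1 to compound 2 (within the scatter), replaced piperidin-1-yl with (2-methoxyethyl)amino on an aromatic carbon and moved the read-out by nothing beyond the usual scatter, so both compounds sit near the low end of the scale in this assay.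

Compound 3 `COCCNc1nc(-c2ccccc2)cc2c1c(N)nn2C` carries the change (phenyl in place of methyl on an aromatic carbon). It sits on an aromatic carbon of the six-membered ring with one nitrogen, meta to the (2-methoxyethyl)amino group and meta and para to the fused ring. For the measured compounds named here, no measured step touches this position or this exchange; the one step in hand concerned a different substituent and was flat. There is therefore no basis in these data for expecting a marked rise or fall, and the expectation for compound 3 in this assay is a step of a number 2 percentage points higher from compound 2 to compound 3 (within the scatter) that stays within the scatter. Compound 3 is accordingly expected to give 8%, with a range from 0% to 30%.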

Compound 3, a percentage reported as inhibition, at one concentration (the size of the read-out at that concentration, not a potency): 8%
Estimate against measurement, compound 3: no gap at the digits printed, within the range that was stated.
By their numbers in this assay, from the lowest: compounds 1, 2 and 3 (each within the scatter of the next).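

In this assay the exchange of methyl for phenyl, on the aromatic carbon next to the ring nitrogen, gave a number 2 percentage points higher from compound 2 to compound 3 (within the scatter). Among the compounds shown here, this is the first reading at this position: the earlier step concerned only the (2-methoxyethyl)amino group, whereas here a single carbon gives way to six heavy atoms and a whole six-membered aromatic ring, and the read-out still does not leave the scatter. All three compounds remain near the low end of the scale at the one concentration tested, so the flat step shows that phenyl brings no measurable gain here, and the data offer no measured property that could account for this result.

From the compounds shown here alone, whether an amine, a carboxylic acid or a longer alkyl chain at this position would read any differently in this assay remains open, as does the effect of a substituted phenyl. Also open, going by these compounds, is whether phenyl would give the same flat result with piperidin-1-yl in place of the (2-methoxyethyl)amino group, since the two exchanges are seen only separately.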